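The compounds below may be only part of what the source reports. "The series", "measured", "known", "first", "only" and "open" are said of these compounds alone.

Of the compounds shown here, three sharing one core have been tested in a functional assay on L5178Y cells (Mus musculus) for inhibition, read by MTT assay, with a stated time of 24 h; on this read-out lower numbers stand for stronger inhibition and higher numbers for weaker inhibition. Compound 1 `CCN(CC)CC(O)COc1ccc([C@@H]2CC(=O)c3c(O)cc(OC)cc3O2)cc1` gives >= 11300 nM, which is a limit of the assay and not a number. Among the measured compounds shown here, compound 2 `COc1cc(O)c2c(c1)O[C@H](c1ccc(OCC(O)CN3CCCCC3)cc1)CC2=O` gives 9300 nM, the only true number so far. Compound 3 `COC(=O)C1CCN(CC(O)COc2ccc([C@@H]3CC(=O)c4c(O)cc(OC)cc4O3)cc2)CC1` gives >= 11300 nM, which is again only a limit. Compound 3 therefore has no exact place on the scale and stands at the limit of >= 11300 nM in this assay, at which 2 of the 3 values shown sit.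

Compound 4 `COc1cc(O)c2c(c1)O[C@H](c1ccc(OCC(O)Cc3c[nH]c4ccccc34)cc1)CC2=O` has not yet been measured. Its change from compound 3 is this: 1H-indol-3-yl in place of 4-(methoxycarbonyl)piperidin-1-yl on a saturated chain carbon, two bonds along the chain from an oxygen on a saturated carbon. Thus 1H-indol-3-yl takes the place of 4-(methoxycarbonyl)piperidin-1-yl on a saturated chain carbon, two bonds along the chain from an oxygen on a saturated carbon.

Earlier swaps at this same place gave an at least 1.2-fold lower number from compound 1 to compound 2 (0.08 log units; that floor lies within the scatter) and a step that the two limits leave unreadable from compound 1 to compound 3. Adding the ester to the ring gave an at least 1.2-fold higher number from compound 2 to compound 3 (0.08 log units; that floor lies within the scatter). None of these steps can be read as lying beyond the scatter, and none of them brought in 1H-indol-3-yl, so they offer only indirect guidance. For the measured compounds named here, with compound 2 at 9300 nM as the only measured number, a result in the same region is expected.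

The expected step is an at least 1.1-fold lower number from compound 3 to compound 4 (0.05 log units; that floor lies within the scatter), which means no clear change in either direction in this assay. The estimate for compound 4 is 10000 nM, with an expected range from 4500 nM to 20000 nM.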

Compound 4, half-maximal inhibitory concentration: >= 11300 nM
Compound 4 gave a limit, no number (the forecaster's own chance of this, stated with the estimate: 45%); middle value at least 1.1-fold (0.05 log units) away from the limit.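

In this assay, compound 4 gives a limit and not a number, so placing 1H-indol-3-yl on the saturated chain carbon, two bonds along the chain from an oxygen on a saturated carbon, does not produce a value clearly apart from that of compound 2. Among the compounds shown here, the only readable step is an at least 1.2-fold higher number from compound 2 to compound 4 (0.08 log units; that floor lies within the scatter); the steps to compound 4 from compound 1 and from compound 3 cannot be read. This position has now carried diethylamino, piperidin-1-yl, 4-(methoxycarbonyl)piperidin-1-yl and 1H-indol-3-yl, and only compound 2 goes against the grouping of these compounds at one limit by giving a true number: the limit of >= 11300 nM in this assay, at which 3 of the 4 values shown sit.

Going by these compounds, how far the true values of compound 1, compound 3 and compound 4 lie from their shared limit remains unknown, so these three compounds cannot be ranked against one another. On these data alone, it also remains open whether a morpholin-4-yl group, a carboxylic acid on the piperidine ring of compound 3 in place of its methoxycarbonyl, or a longer chain leading to the piperidin-1-yl group would give a value clearly beyond the scatter of compound 2.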